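Compound 3 to compound 4: chloro for methoxy

The compounds below may be only part of what the source reports. "The series", "measured", "known", "first", "only" and "open" are said of these compounds alone.

In a functional assay on MCF7 cells (Homo sapiens) for antiproliferative activity, read by MTT assay, with a stated time of 72 h (a lower number here means a stronger inhibitor, a higher number a weaker inhibitor), compound 3 `COc1ncc(-c2ccc3c(c2)N(C2CC2)C(=O)CO3)cc1NS(=O)(=O)c1ccc(F)cc1` gives 35200 nM. Compound 2 `COc1ccc(N2C(=O)COc3ccc(-c4cnc(Cl)c(NS(=O)(=O)c5ccc(F)cc5)c4)cc32)cc1` gives 36000 nM, within the scatter of compound 3. Compound 1 `COc1cccc(N2C(=O)COc3ccc(-c4cnc(Cl)c(NS(=O)(=O)c5ccc(F)cc5)c4)cc32)c1` reads > 40000 nM, which is a limit of the assay and not a number.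

Compound 4 `O=C1COc2ccc(-c3cnc(Cl)c(NS(=O)(=O)c4ccc(F)cc4)c3)cc2N1C1CC1` keeps the group on the amide-type nitrogen of compound 3 and has chloro in place of methoxy on an aromatic carbon.

Going by the values given here, the only measured step, an at least 1.1-fold lower number from compound 1 to compound 2 (0.04 log units; that floor lies within the scatter), is 4-methoxyphenyl in place of 3-methoxyphenyl on an amide-type nitrogen in a ring. It does not test the exchange itself. The closest guide is compound 2, which already carries the chloro group and gives 36000 nM. No step beyond the scatter is therefore expected in this assay.

The estimated step is a 1.2-fold lower number from compound 3 to compound 4 (0.07 log units; within the scatter), and it is not expected to exceed the scatter. For compound 4 the estimated value is 30000 nM, with an expected range of 12000 nM to 55000 nM.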

Compound 4, half-maximal inhibitory concentration: 16700 nM
Compound 4: the middle estimate sits 1.8-fold (0.25 log units) above what was measured; the range from low to high includes it.
By their numbers in this assay, from the lowest: compound 4; then compounds 3 and 2 (each within the scatter of the next). At a limit, above all of these: compound 1.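

In this assay, chloro in place of methoxy on the aromatic carbon next to the ring nitrogen gives a 2.1-fold lower number from compound 3 to compound 4 (0.32 log units; beyond the scatter), so this exchange, read directly here, moves the number beyond the scatter. With chloro held in place, the group on the amide-type nitrogen also matters: cyclopropyl in place of 4-methoxyphenyl gives a 2.2-fold lower number from compound 2 to compound 4 (0.33 log units; beyond the scatter), and cyclopropyl in place of 3-methoxyphenyl gives an at least 2.3-fold lower number from compound 1 to compound 4 (0.37 log units; beyond the scatter). Compound 1 reads as a limit of the assay and not a number: the limit of > 40000 nM in this assay, at which 1 of the 4 values shown sits.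

Still open, from the compounds shown here alone, is whether another group at this position, such as an amine, a nitrile or a methyl, would lower the number further. Also open, going by these compounds, is whether a longer chain or a carboxylic acid on the amide-type nitrogen would do better or worse than cyclopropyl.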